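This account rests on a few compounds, and the source may have more. Where it says the series, first, only, none or still open, it means among the compounds named here.

Measured compounds:
- compound 1, `Cc1ccccc1-n1nncc1CN1C(=O)C2(C(C#N)=C(N)Oc3c2c2nc4ccccc4nc2c2ccccc32)c2ccccc21`, gives in an ADME assay on HUVEC cells (Homo sapiens) for antiproliferative activity, read by MTT assay, with a stated time of 48 h (on this read-out higher numbers stand for weaker inhibition and lower numbers for stronger inhibition), a value that is a limit of the assay rather than a number: > 50000 nM
- compound 2, `N#CC1=C(N)Oc2c(c3nc4ccccc4nc3c3ccccc23)C12C(=O)N(Cc1cnnn1-c1ccccc1Br)c1ccccc12`, gives in this assay likewise only a limit: > 50000 nM

Going by the values given here, compound 2 therefore stands at the limit of this assay, with no number of its own, and the one other value shown is a limit too. The step that the two limits leave unreadable from compound 1 to compound 2, bromo in place of methyl on an aromatic carbon, cannot be read in size because of the limit of > 50000 nM in this assay, at which 2 of the 2 values shown sit.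

Compound 3, `N#CC1=C(N)Oc2c(c3nc4ccccc4nc3c3ccccc23)C12C(=O)N(Cc1cnnn1-c1cccc(S(N)(=O)=O)c1)c1ccccc12`, is still to be measured in this assay. It differs from compound 2 in one place: 3-sulfamoylphenyl in place of 2-bromophenyl on an aromatic nitrogen. No measured step touches this kind of change, and the only step shown is itself unreadable, so there is no basis to expect a movement in this assay beyond the scatter in either direction. The most defensible expectation is that compound 3 also sits at the limit, giving an estimated 50000 nM with a range from 15000 nM to 200000 nM. The step this estimate means is a number no higher from compound 2 to compound 3 (the limit leaves the size open), expected to be flat.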

Compound 3, half-maximal inhibitory concentration: 38600 nM
Compound 3: the middle estimate sits 1.3-fold (0.11 log units) above what was measured; the measured number falls inside the stated range.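

In this assay compound 3 gives 38600 nM, an actual number. The earlier compounds shown here, with 2-methylphenyl and 2-bromophenyl on the aromatic nitrogen, gave only limits. This position therefore accepts a larger aromatic group carrying a sulfamoyl group and still yields a readable value, which the earlier pair could not show. Replacing 2-bromophenyl with 3-sulfamoylphenyl gives an at least 1.2-fold lower number from compound 2 to compound 3 (0.11 log units; that floor lies within the scatter), and replacing 2-methylphenyl with it gives an at least 1.2-fold lower number from compound 1 to compound 3 (0.11 log units; that floor lies within the scatter), but each is only a floor, so no real gain can be claimed, and the true size stays hidden because both starting values are limits: the limit of > 50000 nM in this assay, at which 2 of the 3 values shown sit.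

As far as these compounds go, it remains open whether this readable value depends on the sulfamoyl group itself, which a phenyl ring carrying a carboxylic acid or an amine in its place would help to test. From the compounds shown here alone, it is also open whether a longer alkyl chain in place of the phenyl ring on this nitrogen would give a number or stay at the limit.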